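The compounds below may be only part of what the source reports. "The series", "measured", "known", "first", "only" and "open" are said of these compounds alone.

Measured so far:
compound 1 `CCCCCOc1cccc(C(=O)Nc2cccc(C(=O)O)c2)c1`, 2540 nM
compound 2 `O=C(O)c1cccc(NC(=O)c2ccc(OCc3cccc(-c4ccccc4)c3)cc2)c1`, 319 nM

In an assay on isolated protein for agonist activity at Bile acid receptor (Homo sapiens), read by TR-FRET, with a stated time of 3 h, in the absence of a further agent (on this read-out higher numbers stand for an effect only at larger amounts of compound and lower numbers for an effect already at smaller amounts), compound 1 stands at the higher of the two numbers; the gap to compound 2 lies beyond the scatter. Compound 3 `Cc1ccc(COc2cccc(C(=O)Nc3cccc(C(=O)O)c3)c2)cc1` differs from compound 1 by 4-methylphenyl in place of butyl on a saturated chain carbon bound to an oxygen on an aromatic ring. Among the measured compounds shown here, no step between measured compounds covers this change on its own. Compound 2, which also carries an aromatic ring in its ether, gives the lower number of the two, so a moderate move toward lower numbers is expected, a 2.8-fold lower number from compound 1 to compound 3 (0.45 log units; beyond the scatter). Compound 3 is estimated at 900 nM, with a range from 300 nM to 2700 nM.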

Compound 3, half-maximal effective concentration: 1430 nM
Compound 3: the middle estimate sits 1.6-fold (0.20 log units) below what was measured; low and high end bracket the measured number.
By their numbers in this assay, from the lowest: compound 2; then compounds 3 and 1 (each within the scatter of the next).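

In this assay, 4-methylphenyl in place of butyl on a saturated chain carbon bound to an oxygen on an aromatic ring gives a 1.8-fold lower number from compound 1 to compound 3 (0.25 log units; within the scatter). This position therefore accepts an aromatic ring in place of an open chain, and the two compounds cannot be told apart here. No separate measurement bears on this result.

Still open, on these data alone, is whether an amine on that aromatic ring, or a heptyl chain in place of butyl, would give a number beyond the scatter from compound 1.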